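Methoxy in place of chloro on the amide-bearing ring

A few compounds are considered here, and "the series" means these few. Any claim that something is new, unique, unknown or untested is made for them only; others in the source may bear on it.

Of the compounds shown here, two sharing one core have been measured. Compound 1 `O=C(Nc1ccc(F)cc1)c1cncc(N2CC3CC(C2)N3)c1` carries a 4-fluorophenyl group on the amide nitrogen, and in an assay on cells for agonist activity at Neuronal acetylcholine receptor; alpha4/beta2 (Homo sapiens), read by patch clamp, with a stated time of 4 days (on this read-out lower numbers stand for smaller maximal responses and higher numbers for larger maximal responses), compound 1 gives 41%. Compound 2 `O=C(Nc1cccc(Cl)c1)c1cncc(N2CC3CC(C2)N3)c1` carries a 3-chlorophenyl group in the same position, and in this assay compound 2 gives 37%. Within the data shown here, the only step available, a number 4 percentage points lower from compound 1 to compound 2 (within the scatter), is one that the usual scatter of this kind of measurement can account for, so the two numbers are best read as the same.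

Compound 3 `COc1cccc(NC(=O)c2cncc(N3CC4CC(C3)N4)c2)c1` differs from compound 2 by a single exchange: methoxy in place of chloro on an aromatic carbon. Among the measured compounds shown here, the one measured step also altered the group on this ring, and it produced no movement beyond the scatter. For the measured compounds named here, no measured step involves a methoxy group, so the expectation rests on that single small step alone.

Compound 3 is therefore expected to show 39% in this assay, with a range from 25% to 55%. In step form this is an expected a number 2 percentage points higher from compound 2 to compound 3 (within the scatter), that is, no change beyond the scatter.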

Compound 3, largest response reached (reported as Imax), in percent of the reference or control that the assay uses: 38%
The estimate for compound 3 lay 1 percentage points above the measured number; the measured number falls inside the stated range.
By their numbers in this assay, from the lowest: compounds 2, 3 and 1 (each within the scatter of the next).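

In this assay, the exchange at this place on the ring, meta to a large group, gives a number 1 percentage points higher from compound 2 to compound 3 (within the scatter), so a methoxy group, with its extra heavy atom and its hydrogen-bond acceptor, reads the same here as chloro. Set against the 4-fluorophenyl group on the amide nitrogen, the 3-methoxyphenyl group gives a number 3 percentage points lower from compound 1 to compound 3 (within the scatter), so all three compounds now sit within the scatter of one another, and the earlier single step has become a small flat set covering three different aromatic groups on that nitrogen. Nothing available here bears on why these exchanges leave the maximal response unmoved.

All three groups shown are small and uncharged, so it remains open whether the same flat reading would hold for an amine or a carboxylic acid at this place on the ring, or for a longer chain such as butoxy in place of methoxy. As far as these compounds go, it also remains open whether a plain phenyl ring, with no group on it at all, would read the same as these three.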